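The source may hold more compounds than are shown below. What is called first, only, known or untested is meant among the compounds shown, and "the series" means these compounds.

Measured compounds:
- compound 1, `CC1CCN(c2c(S(=O)(=O)c3cc(Cl)cc(Cl)c3)cnc3ccc(F)cc23)CC1`: 69%
- compound 2, `Cc1ccc(S(=O)(=O)c2cnc3ccc(F)cc3c2N2CCC(C)CC2)cc1C`: 92%
- compound 3, `COc1ccc(S(=O)(=O)c2cnc3ccc(F)cc3c2N2CCC(C)CC2)cc1`: 85%

All three share a core and differ only in the aryl group on the sulfonyl sulfur. In an assay on isolated protein for displacement of a labelled ligand from metabotropic glutamate receptor 5 (Homo sapiens), with a stated time of 60 min, tested at 1 uM (on this read-out lower numbers stand for less inhibition and higher numbers for more inhibition at the one concentration tested (going by the name of the read-out)), compound 3 stands second highest of the three. Its nearest neighbour is compound 2, and a number 7 percentage points lower from compound 2 to compound 3 (within the scatter) lies within the scatter, so the two cannot be ordered. Against compound 1 the gap is clearer: a number 16 percentage points higher from compound 1 to compound 3 (beyond the scatter).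

Compound 4, `CC1CCN(c2c(S(=O)(=O)c3ccc(Cl)cc3)cnc3ccc(F)cc23)CC1`, is not yet measured. It differs from compound 3 by chloro in place of methoxy on an aromatic carbon. For the measured compounds named here, no measured pair shows exactly this swap. The closest guide is compound 1, whose 3,5-dichlorophenyl sits lower than both the 3,4-dimethylphenyl of compound 2 (a number 23 percentage points higher from compound 1 to compound 2 (beyond the scatter)) and the 4-methoxyphenyl of compound 3. A single chloro on the same ring is a smaller departure from compound 3 than two, so a step of modest size downward, or none beyond the scatter, is expected in this assay.

For compound 4 the expected value is 78%, with a likely range from 62% to 92%, which corresponds to an estimated step of a number 7 percentage points lower from compound 3 to compound 4 (within the scatter).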

Compound 4, a percentage reported as inhibition, at one concentration (the size of the read-out at that concentration, not a potency): 80%
Beside the measured number, compound 4's estimate is 2 percentage points below it; the measured number falls inside the stated range.
By their numbers in this assay, from the lowest: compound 1; then compounds 4, 3 and 2 (each within the scatter of the next, the first and the last beyond it).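

In this assay the swap of methoxy for chloro, on the aromatic carbon para to a large group, gives a number 5 percentage points lower from compound 3 to compound 4 (within the scatter) and so leaves these two compounds unordered, even though chloro, unlike methoxy, carries no hydrogen-bond acceptor. The comparison with the dichlorinated compound gives a number 11 percentage points higher from compound 1 to compound 4 (beyond the scatter) as the ring changes from 3,5-dichlorophenyl to 4-chlorophenyl, which shows that a chloro on this ring does not by itself bring the number down to the level of compound 1. The 3,4-dimethylphenyl group also stays apart from the new ring, with a number 12 percentage points lower from compound 2 to compound 4 (beyond the scatter), so the series now has a measurable spread at the top even though neighbouring members cannot be separated.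

Nothing measured here explains why these aryl groups differ, so the reason for the steps remains unknown. Also open, as far as these compounds go, is how an amine or a carboxylic acid at the same place on the ring would read, and with only one concentration tested, these percentages do not show how potency compares across the compounds.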